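Amino for hydroxy on two related nucleoside cores

The source may hold more compounds than are shown below. What is called first, only, known or untested is meant among the compounds shown, and "the series" means these compounds.

Compound 1 `N#C[C@]1(O)[C@H](O)[C@@H](CO)O[C@@H](n2ccc(O)nc2=O)[C@@H]1O` — 417000 nM in a functional assay on L1210 cells (Mus musculus); a higher number here means a weaker inhibitor, a lower number a stronger inhibitor
Compound 2 `N#C[C@]1(O)[C@H](O)[C@@H](CO)O[C@@H](n2ccc(N)nc2=O)[C@@H]1O` — 147000 nM
Compound 3 `N#C[C@H]1[C@@H](O)[C@H](n2ccc(O)nc2=O)O[C@H](CO)[C@H]1O` — in this assay compound 3 reaches only the limit of > 500000 nM, not a number.

Compound 1 and compound 2 share one core and differ by amino in place of hydroxy on an aromatic carbon; this change gave a 2.8-fold lower number from compound 1 to compound 2 (0.45 log units; beyond the scatter). How the core of compound 3 differs from the core of compound 1 is not broken down here. Compound 4 `N#C[C@H]1[C@@H](O)[C@H](n2ccc(N)nc2=O)O[C@H](CO)[C@H]1O` has not yet been measured; it differs from compound 3 by amino in place of hydroxy on an aromatic carbon, the same change. For compound 3, the measurement is a limit (the limit of > 500000 nM in this assay, at which 1 of the 3 values shown sits). The step to compound 4 is expected to be similar to the earlier one, roughly an at least 1.4-fold lower number from compound 3 to compound 4 (0.15 log units; that floor lies within the scatter), resting on what compound 1 to compound 2 showed. Compound 4 is thus estimated at about 350000 nM, with a real chance that this assay again reports only a limit.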

Compound 4, half-maximal inhibitory concentration: > 750000 nM
Compound 4 ended at the assay's limit; the forecaster's own chance of this, stated with the estimate: 50%; middle value at least 2.1-fold (0.33 log units) away from the limit.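

Compound 3 and compound 4 both gave only limits, not numbers, so the step between them cannot be read. Still open, going by these compounds, is whether amino in place of hydroxy changes the number on this core as it did between compound 1 and compound 2.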